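A few compounds are considered here, and "the series" means these few. Any claim that something is new, unique, unknown or untested is made for them only; others in the source may bear on it.

Compound 1 `COc1ccc(N2CCN(Cc3csc(N)c3C(=O)c3ccc(Cl)cc3)CC2)cc1`: -52%
Compound 2 `Nc1scc(CN2CCN(c3cccc(C(F)(F)F)c3)CC2)c1C(=O)c1ccc(Cl)cc1`: -80%
Compound 3 `Nc1scc(CN2CCN(c3c(F)cccc3F)CC2)c1C(=O)c1ccc(Cl)cc1`: -80%

Of the compounds shown here, three sharing one core have been tested in a functional assay on CHO cells with adenosine receptor A1 (Homo sapiens) as the target, read by cAMP accumulation and immunoassay, with a stated time of 6 min, tested at 10 uM; a higher number here means a weaker effect of the compound at the concentration tested, a lower number a stronger effect; they differ only in the aryl group carried on an amine nitrogen in a ring. Compound 3 stands level with compound 2 at the digits printed, and together they give the lowest of the three numbers; compound 1 sits a number 28 percentage points lower from compound 1 to compound 3 (beyond the scatter) apart, a difference beyond the scatter. The parallel step a number 28 percentage points lower from compound 1 to compound 2 (beyond the scatter) is of the same size, whereas no change at the digits printed from compound 2 to compound 3 (within the scatter).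

Compound 4 `Nc1scc(CN2CCN(c3c(F)cc(F)cc3F)CC2)c1C(=O)c1ccc(Cl)cc1` is made from compound 3 by one change: fluoro in place of hydrogen on an aromatic carbon. For the measured compounds named here, no measured step adds a single fluoro in this way, but the exchange of one fluorinated or halogenated aryl group for another, no change at the digits printed from compound 2 to compound 3 (within the scatter), left this assay unchanged, and that is the closest guide. A step of a number 2 percentage points higher from compound 3 to compound 4 (within the scatter) is therefore expected, nothing beyond the scatter. Compound 4 is estimated at -78%, within -95% to -60%.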

Compound 4, a percentage reported as activity, at one concentration (the size of the read-out at that concentration, not a potency): -78%
Estimate against measurement, compound 4: no gap at the digits printed; measured number inside the range.
By their numbers in this assay, from the lowest: compounds 2, 3 and 4 (each within the scatter of the next); then compound 1.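

For the compounds shown here, on the 2,6-difluorophenyl ring, the aromatic carbon para to a large group takes a third fluoro with little effect in this assay (a number 2 percentage points higher from compound 3 to compound 4 (within the scatter)), which is the first single fluoro addition seen in this set. The resulting 2,4,6-trifluorophenyl group also matches the 3-(trifluoromethyl)phenyl group (a number 2 percentage points higher from compound 2 to compound 4 (within the scatter)) and keeps its separation from the 4-methoxyphenyl group (a number 26 percentage points lower from compound 1 to compound 4 (beyond the scatter)), so all three fluorinated aryl groups now read alike, apart from compound 1. No independent evidence is available to explain this result.

The compounds shown leave open whether a chloro, a nitrile or an amine on this same carbon would read the same way. They also leave open how a plain phenyl ring, carrying no fluoro at all, would compare.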